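The source may hold more compounds than are shown below. What is called first, only, known or untested is meant among the compounds shown, and "the series" means these compounds.

Of the compounds shown here, three built on one shared core have been tested in a functional assay on 4T1 cells (Homo sapiens) for cytotoxicity, read by MTT assay, with a stated time of 48 h; on this read-out lower numbers stand for stronger inhibition and higher numbers for weaker inhibition. Compound 1, `CC(C)n1c(/C=C2/C(=O)Nc3ccccc32)nc2ccccc21`, gives 40400 nM in this assay. Compound 2, `CCn1c(/C=C2/C(=O)Nc3ccc(Br)cc32)nc2ccccc21`, gives 40700 nM in this assay. Compound 3, `Cn1c(/C=C2/C(=O)Nc3ccc([N+](=O)[O-])cc32)nc2ccccc21`, reaches only the limit of this assay, > 50000 nM, so for it no number is known. Compound 3 therefore stands at the limit of > 50000 nM in this assay, at which 1 of the 3 values shown sits, while the two compounds with numbers sit somewhat under that mark, and those two numbers lie within the usual scatter of one another.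

Compound 4, `Cn1c(/C=C2/C(=O)Nc3ccc(Br)cc32)nc2ccccc21`, has not yet been measured. It differs from compound 3 in one place: bromo in place of nitro on an aromatic carbon. Compound 2 carries the same bromo group and gives 40700 nM in this assay; compound 1 carries neither bromo nor nitro and gives 40400 nM in this assay.

For the measured compounds named here, no step between two measured compounds is available here, so the expectation rests on these values alone. The step from compound 3 to compound 4 is expected to be an at least 1.1-fold lower number from compound 3 to compound 4 (0.07 log units; that floor lies within the scatter), a shift towards stronger inhibition that may not exceed the scatter. Compound 4 is expected to give about 42000 nM in this assay, within 20000 nM to 80000 nM, and it may itself come out as a limit.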

Compound 4, half-maximal inhibitory concentration: > 50000 nM
Compound 4: a limit, no number; the forecaster's own chance of this, stated with the estimate: 40%; middle value at least 1.1-fold (0.07 log units) from the limit.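

Compound 3 and compound 4 both end at a limit of this assay, so the step between them cannot be read, and bromo on this aromatic carbon cannot be placed higher or lower than nitro. That leaves the change from nitro to bromo without a size, and the count at the limit now reads: the limit of > 50000 nM in this assay, at which 2 of the 4 values shown sit.

For the compounds shown here, the one readable comparison concerns the chain on the aromatic nitrogen, not the ring position: with bromo kept in place, going from ethyl to methyl gives an at least 1.2-fold higher number from compound 2 to compound 4 (0.08 log units; that floor lies within the scatter). Going by these compounds, this step is only a floor, so its true size remains unknown, and what is printed does not show a change beyond ordinary scatter.

On these data alone, it remains open whether another group on this aromatic carbon, such as an amine or a methoxy group, would bring a value clear of the limit in this assay. Also open, as far as these compounds go, is whether a longer chain on the aromatic nitrogen, such as propyl or butyl, would give a number different from that of the ethyl chain when bromo is kept.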